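This account rests on a few compounds, and the source may have more. Where it says the series, first, only, none or still open, it means among the compounds named here.

Values in an ADME assay on Vero cells (Chlorocebus sabaeus) for cytotoxicity; a higher number here means that more compound is tolerated, a lower number that less compound is tolerated:
- compound 1 `CNc1nc(Nc2ccc(C(C)=O)cc2)c2nc[nH]c2n1`: > 177000 nM (a limit)
- compound 2 `Cc1cc(OCc2ccc(F)cc2F)cc(=O)n1Cc1ccc(C(F)(F)F)cc1`: < 4800 nM (a limit)
- compound 3 `CC(=O)c1ccc(Nc2nc(NCCC(C)C)nc3[nH]cnc23)cc1`: 85000 nM

Among the compounds with values here, compound 3 holds the only true number in this set, since the other two entries are limits of the assay. Its value of 85000 nM therefore cannot be ranked precisely against them. Within the data shown here, compound 2 does not share the core of compound 1 and gives no step here.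

The next compound is compound 4 `CC(=O)c1ccc(Nc2nc(NCCO)nc3[nH]cnc23)cc1`, which keeps the core of compound 3 and changes only the end of the chain. The change is hydroxy in place of isopropyl on a saturated chain carbon, two bonds along the chain from a nitrogen on an aromatic ring, and it turns isopentylamino into (2-hydroxyethyl)amino.

Among the measured compounds shown here, one measured step bears on this: an at least 2.0-fold lower number from compound 1 to compound 3 (0.31 log units; beyond the scatter). That step added isobutyl, and the change to compound 4 removes the isopropyl end of the same chain. It is a single step, and it ends in a limit on one side, so the support is thin. A move back toward a higher number is expected, of modest size, and a report as a limit is about as likely as a number.

The expected change is a 2.0-fold higher number from compound 3 to compound 4 (0.30 log units; within the scatter) in this assay.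

For compound 4 the estimate is 170000 nM, with an expected range from 90000 nM to 320000 nM.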

Compound 4, half-maximal cytotoxic concentration: 160000 nM
Beside the measured number, compound 4's estimate is 1.1-fold (0.03 log units) above it; measured number inside the range.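

In this assay, the change from isopentylamino to (2-hydroxyethyl)amino gives a 1.9-fold higher number from compound 3 to compound 4 (0.27 log units; within the scatter), so hydroxy in place of isopropyl, on a saturated chain carbon, two bonds along the chain from a nitrogen on an aromatic ring, does not move the number past the scatter. As a change of the chain, (2-hydroxyethyl)amino gives an at least 1.1-fold lower number from compound 1 to compound 4 (0.04 log units; that floor lies within the scatter), whereas isopentylamino gives an at least 2.0-fold lower number from compound 1 to compound 3 (0.31 log units; beyond the scatter), so only the isopentylamino step is printed as beyond the scatter. The value of compound 1 is a limit, so both of these steps give floors and not sizes: the limit of > 177000 nM in this assay, at which 1 of the 4 values shown sits.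

Still open, from the compounds shown here alone, is how an amine or a carboxylic acid at the end of this chain would read in this assay, and whether a longer chain ending in hydroxy would stay within the scatter of compound 4. With only one hydroxy-bearing chain among these compounds, no trend with chain length can be read from them.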